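This account rests on a few compounds, and the source may have more. Where it says the series, first, only, none or still open, it means among the compounds named here.

Compound 3 `Cc1csc(-c2cc(C(O)(C(F)(F)F)C(F)(F)F)cnc2N2CCN(S(=O)(=O)c3ccc(N)nc3)CC2)c1` belongs to a small set studied in an ADME assay (liver) for metabolic stability, with Liver microsome (Rattus norvegicus) as the target, using microsomes and NADPH, with a stated time of 30 min, tested at 1 uM; a lower number here means slower removal, a higher number faster removal of the compound. In this assay compound 3 gives 399 mL.min-1.g-1, and compound 2 `COCC#Cc1cc(C(O)(C(F)(F)F)C(F)(F)F)cnc1N1CCN(S(=O)(=O)c2ccc(N)nc2)CC1` gives 399 mL.min-1.g-1; the two stand level, and together they are the highest of the three numbers. Compound 1 `Nc1ccc(S(=O)(=O)N2CCN(c3ncc(C(O)(C(F)(F)F)C(F)(F)F)cc3C3CC3)CC2)cn1` gives 27 mL.min-1.g-1, and the step of a 15-fold higher number from compound 1 to compound 3 (1.17 log units; beyond the scatter) is the large one in the set, while no change at the digits printed from compound 2 to compound 3 (within the scatter) shows nothing beyond the scatter.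

Compound 4 `Nc1ccc(S(=O)(=O)N2CCN(c3ncc(C(O)(C(F)(F)F)C(F)(F)F)cc3-c3ccc4sccc4c3)CC2)cn1` differs from compound 3 by 1-benzothiophen-5-yl in place of 4-methylthiophen-2-yl on an aromatic carbon. Both steps that replaced the cyclopropyl of compound 1 with an aromatic group, a 15-fold higher number from compound 1 to compound 2 (1.17 log units; beyond the scatter) and a 15-fold higher number from compound 1 to compound 3 (1.17 log units; beyond the scatter), raised the number, and swapping one such group for another, no change at the digits printed from compound 2 to compound 3 (within the scatter), changed nothing; so for compound 4 the expected step is a 1.0-fold higher number from compound 3 to compound 4 (0.00 log units; within the scatter), essentially none. Compound 4 is therefore estimated at 400 mL.min-1.g-1, within 200 mL.min-1.g-1 to 800 mL.min-1.g-1.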

Compound 4, intrinsic clearance in microsomes: 487 mL.min-1.g-1
For compound 4 the middle estimate is 1.2-fold (0.09 log units) below the measured one, and the stated range covers the measured number.
By their numbers in this assay, from the lowest: compound 1; then compounds 2, 3 and 4 (each within the scatter of the next).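

On this aromatic carbon, a group with a second fused ring gives much the same result as the smaller groups in this assay: 1-benzothiophen-5-yl gives a 1.2-fold higher number from compound 3 to compound 4 (0.09 log units; within the scatter) and a 1.2-fold higher number from compound 2 to compound 4 (0.09 log units; within the scatter). The large gap remains only against cyclopropyl, with an 18-fold higher number from compound 1 to compound 4 (1.26 log units; beyond the scatter), so compound 1 alone stands apart among the four. No measurement here bears on the reason for that gap. On these data alone, it remains open whether a methyl group, a morpholine or another saturated ring at this position would give a low number like that of compound 1.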